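The compounds below may be only part of what the source reports. "The series", "measured", "known", "first", "only" and "open" are said of these compounds alone.

Compound 2 `O=c1[nH]c(=O)n(C2C[C@@H](O)[C@@H](CO)O2)nc1-c1ccoc1` carries a furan-3-yl group on the shared core. For the measured compounds named here, in a functional assay on Vero cells (Chlorocebus sabaeus) for cytotoxicity (a lower number here means a stronger inhibitor, a higher number a weaker inhibitor), compound 2 gives 45 ug/mL, the only number among the two values shown. Compound 1 `O=c1[nH]c(=O)n(C2C[C@@H](O)[C@@H](CO)O2)nc1/C=C/Cl` carries 2-chloroethenyl in that place. In this assay compound 1 reports only a limit, > 500 ug/mL, and not a number (the limit of > 500 ug/mL in this assay, at which 1 of the 2 values shown sits). Going by the values given here, the single measured step is large: an at least 11-fold lower number from compound 1 to compound 2 (1.04 log units; beyond the scatter).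

Compound 3 `O=Cc1nn(C2C[C@@H](O)[C@@H](CO)O2)c(=O)[nH]c1=O` has not yet been measured in this assay. It differs from compound 2 as follows: formyl in place of furan-3-yl on an aromatic carbon.

Among the compounds with values here, only the step from 2-chloroethenyl to furan-3-yl bears on this change, and it was an at least 11-fold lower number from compound 1 to compound 2 (1.04 log units; beyond the scatter). Replacing the furan-3-yl with the smaller formyl group removes the very group whose entry gave that large lower number, so compound 3 is expected to show a higher number in this assay, with a step of a 5.6-fold higher number from compound 2 to compound 3 (0.74 log units; beyond the scatter) expected, and a fair chance that only a limit is reported. The estimate for compound 3 in this assay is 250 ug/mL, expected to lie between 50 ug/mL and 600 ug/mL.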

Compound 3, concentration for 50% inhibition: 180 ug/mL
Beside the measured number, compound 3's estimate is 1.4-fold (0.14 log units) above it, and the stated range covers the measured number.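

The new compound shows that this position does not depend on the furan-3-yl ring alone for a lower number in this assay. Losing that ring costs only part of the ground, with a 4.0-fold higher number from compound 2 to compound 3 (0.60 log units; beyond the scatter), yet formyl, with no ring and fewer heavy atoms, still stands apart from 2-chloroethenyl, with an at least 2.7-fold lower number from compound 1 to compound 3 (0.44 log units; beyond the scatter). Compound 1 reports a limit and not a number, so the second step is only a bound and the full span across the three groups stays unknown: the limit of > 500 ug/mL in this assay, at which 1 of the 3 values shown sits.

The compounds shown leave open how an amine, a carboxylic acid or a longer chain on this aromatic carbon would stand in this assay, and whether any of these would fall with furan-3-yl, with formyl or with 2-chloroethenyl. They also leave open how far compound 1 really lies from the other two, and three groups are too few to tie the read-out to ring content or to the count of heavy atoms.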